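Chloro for methoxy on the aryl arm of compound 1

The compounds below may be only part of what the source reports. "The series", "measured", "known", "first", "only" and "open" are said of these compounds alone.

In an ADME assay on microsomes from liver (Homo sapiens) for metabolic stability, tested at 2.5 uM (on this read-out lower numbers stand for slow clearance and higher numbers for fast clearance), compound 1 `COc1cccc(-c2c(S(=O)(=O)c3cc(Cl)cc(Cl)c3)cnc3c(F)cccc23)c1` gives 2.31 mL/min, the lowest of the three numbers recorded, though its companions sit within the scatter of it: compound 2 `COc1cccc(-c2c(S(=O)(=O)c3ccc(C)c(F)c3)cnc3c(F)cccc23)c1` gives 4.02 mL/min and compound 3 `COc1ccc(S(=O)(=O)c2cnc3c(F)cccc3c2-c2cccc(OC)c2)cc1` gives 2.87 mL/min. The recorded steps, a 1.7-fold higher number from compound 1 to compound 2 (0.24 log units; within the scatter), a 1.2-fold higher number from compound 1 to compound 3 (0.09 log units; within the scatter) and a 1.4-fold lower number from compound 2 to compound 3 (0.15 log units; within the scatter), all concern the aryl group on the sulfonyl sulfur and all stay within the scatter. Compound 4 `O=S(=O)(c1cc(Cl)cc(Cl)c1)c1cnc2c(F)cccc2c1-c1cccc(Cl)c1` differs from compound 1 elsewhere: chloro in place of methoxy on an aromatic carbon. Within the data shown here, no measured step touches that position, so nothing in the data points in either direction, and a step within the scatter is expected, a 1.1-fold lower number from compound 1 to compound 4 (0.04 log units; within the scatter). Compound 4 is therefore estimated at 2.1 mL/min in this assay, between 1 mL/min and 4.2 mL/min.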

Compound 4, intrinsic clearance in a liver preparation (reported as CLH), per the amount of preparation that the assay uses: 1.2 mL/min
Estimate against measurement, compound 4: 1.8-fold (0.24 log units) above, and the stated range covers the measured number.
By their numbers in this assay, from the lowest: compounds 4, 1, 3 and 2 (each within the scatter of the next, the first and the last beyond it).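

The first measured change on the aryl arm, 3-methoxyphenyl to 3-chlorophenyl, gives a 1.9-fold lower number from compound 1 to compound 4 (0.28 log units; within the scatter) in this assay, so this position, like the aryl group on the sulfonyl sulfur, has so far shown no step beyond the scatter. Thus chloro can replace methoxy on this aromatic carbon with the 3,5-dichlorophenyl sulfone kept in place, with no clear shift in clearance. No supporting measurement bears on why the number falls where it does. On these data alone, how an amine or a carboxylic acid on the same aromatic carbon would read in this assay remains open.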